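Nucleoside analogues on leukaemia cells: amino against hydroxy

The source may report more compounds than this note shows. Statements on the series, on what has been measured and on what is new or still open speak of the compounds shown alone.

Compound 1 `C=C1[C@@H](O)[C@H](n2cnc3c(N)ncnc32)O[C@@H]1CO` and compound 2 `C=C1[C@@H](O)[C@H](n2cnc3c(O)ncnc32)O[C@@H]1CO` share one core; compound 3 `C=C1[C@H](n2cnc3c(N)ncnc32)O[C@H](CO)[C@H]1O` and compound 4 `C=C1[C@H](n2cnc3c(O)ncnc32)O[C@H](CO)[C@H]1O` share another, and the difference between the two cores is not broken down here. In a functional assay on L1210 cells (Mus musculus) for inhibition (on this read-out higher numbers stand for weaker inhibition and lower numbers for stronger inhibition), compound 1 gives 228000 nM. Compound 2 reaches only a limit of the assay, > 200000 nM. The change between them, (hydroxy in place of amino on an aromatic carbon), therefore gives a step that the limit leaves unreadable from compound 1 to compound 2 because of the limit of > 200000 nM in this assay, at which 1 of the 3 values shown sits. In this assay compound 3 gives 65000 nM. Compound 4 carries the same change, (hydroxy in place of amino on an aromatic carbon). The step from compound 3 to compound 4 is expected to be a 3.8-fold higher number from compound 3 to compound 4 (0.59 log units; beyond the scatter), resting on compound 2 sitting at the limit of > 200000 nM in this assay, at which 1 of the 3 values shown sits, after the same change. Compound 4 is expected to give about 250000 nM in this assay, between 90000 nM and 800000 nM, most likely as a limit.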

Compound 4, half-maximal inhibitory concentration: 60000 nM
The estimate for compound 4 lay 4.2-fold (0.62 log units) above the measured number, outside the stated range (below it).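

In this assay, hydroxy in place of amino on the core of compound 3 gives a 1.1-fold lower number from compound 3 to compound 4 (0.03 log units; within the scatter), so on this core the two groups cannot be told apart. This does not show that the result carries over to the other core, nor that it fails to. The matching step from compound 1 to compound 2 cannot be read, because compound 2 gives only a limit: the limit of > 200000 nM in this assay, at which 1 of the 4 values shown sits.

The compounds shown leave open whether another group on this aromatic carbon, such as methoxy, methylamino or chlorine, would move the number beyond the scatter on either core. Among these compounds, with one change seen on only two cores, and only one of its steps readable, no rule for the wider series can be drawn.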